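Aryl piperazine variation on the shared oxazole core

The source may report more compounds than this note shows. Statements on the series, on what has been measured and on what is new or still open speak of the compounds shown alone.

Of the compounds shown here, three have been measured in an assay on HEK293 cells for inhibition of Voltage-dependent T-type calcium channel subunit alpha-1G (Homo sapiens), read by fluorescence, tested at 10 uM; a higher number here means more inhibition at the concentration tested (going by the name of the read-out), a lower number less inhibition. Compound 3 `CCCc1nc(-c2ccccc2)c(CNCCN2CCN(c3ccc(C)cc3)CC2)o1` gives 48.1%, the highest of the three numbers. Compound 1 `CCCc1nc(-c2ccccc2)c(CNCCN2CCN(c3cccc(C)c3)CC2)o1` gives 43.1%, and compound 2 `CCCc1nc(-c2ccccc2)c(CNCCN2CCN(c3ccccc3OC)CC2)o1` gives 39.7%. The step from compound 1 to compound 3 was a number 5 percentage points higher from compound 1 to compound 3 (within the scatter), and from compound 2 to compound 3 it was a number 8.4 percentage points higher from compound 2 to compound 3 (within the scatter), so the three aryl groups on the piperazine nitrogen are not separated beyond the scatter of this assay.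

Compound 4 `CCCc1nc(-c2ccccc2)c(CNCCN2CCN(c3ccccc3C(F)(F)F)CC2)o1` is the next member. The change from compound 3 is 2-(trifluoromethyl)phenyl in place of 4-methylphenyl on an amine nitrogen in a ring. Going by the values given here, the measured steps all concern exchanges of the aryl group on the same ring nitrogen, and none of them moved the number beyond the scatter; the step from compound 2 to compound 3, the one that also changes the position of the substituent, is the largest but still within it. Among the compounds with values here, no step to a trifluoromethyl-bearing aryl group exists in the set. The step from compound 3 to compound 4 is therefore expected to be small, estimated as a number 5.1 percentage points lower from compound 3 to compound 4 (within the scatter), with no direction claimed beyond the scatter. For compound 4 in this assay the estimate is 43%, expected to fall between 26% and 60%.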

Compound 4, a percentage reported as inhibition, at one concentration (the size of the read-out at that concentration, not a potency): 54.6%
Beside the measured number, compound 4's estimate is 11.6 percentage points below it; measured number inside the range.
By their numbers in this assay, from the lowest: compounds 2, 1, 3 and 4 (each within the scatter of the next, the first and the last beyond it).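

In this assay, going by these compounds alone, the aryl group on this ring nitrogen separates compounds beyond the scatter for the first time: trifluoromethyl in place of methoxy on the aromatic carbon gives a number 14.9 percentage points higher from compound 2 to compound 4 (beyond the scatter) and 2-(trifluoromethyl)phenyl in place of 3-methylphenyl gives a number 11.5 percentage points higher from compound 1 to compound 4 (beyond the scatter) in the same direction. The exchange for 4-methylphenyl gives only a number 6.5 percentage points higher from compound 3 to compound 4 (within the scatter) and so does not separate these two aryl groups, which leaves compound 3 against any simple reading of the trifluoromethyl group as the sole route to a higher number. Nothing at hand bears on the reason for these steps.

Open, going by these compounds, is whether a plain phenyl or a nitrile-bearing phenyl on the same ring nitrogen would group with compound 4 or with compound 2. On these data alone, the shared core stays fixed throughout, so whether the methoxy to trifluoromethyl step holds on a core with a longer chain also remains open.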